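The source may hold more compounds than are shown below. What is called first, only, known or untested is meant among the compounds shown, and "the series" means these compounds.

Four compounds share a core built from the same fused ring system, each carrying a phenyl ring at one position and an amine-bearing side chain at another. Compound 1, `CCOC(=O)c1csc2nc(CN3CCN(C)CC3)c(-c3ccc(OC)cc3)n12`, bears a methoxy group on its phenyl ring and an ester on the core. In a functional assay on HeLa cells (Homo sapiens) for antiproliferative activity, read by MTT assay, with a stated time of 72 h (a lower number here means a stronger inhibitor, a higher number a weaker inhibitor), compound 1 gives 35100 nM. Compound 2, `CCOC(=O)c1csc2nc(CN3CCN(C)CC3)c(-c3ccc(Br)cc3)n12`, differs from compound 1 by a single change, (bromo in place of methoxy on an aromatic carbon). In this assay compound 2 gives 55400 nM, and a 1.6-fold higher number from compound 1 to compound 2 (0.20 log units; within the scatter).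

Compound 3, `COc1ccc(-c2c(CN3CCCCC3)nc3scc(C(=O)O)n23)cc1`, carries a free carboxylic acid on the core and a piperidine side chain, and in this assay compound 3 gives 47400 nM. The difference between the core of compound 3 and that of compound 1 is not broken down here; the two values, however, sit close together.

Compound 4, `O=C(O)c1csc2nc(CN3CCCCC3)c(-c3ccc(Br)cc3)n12`, is related to compound 3 by the same kind of change that connects compound 1 to compound 2: bromo in place of methoxy on an aromatic carbon. The place of the change is described in the same words in both pairs. Within the data shown here, the only guide is the earlier pair, where a 1.6-fold higher number from compound 1 to compound 2 (0.20 log units; within the scatter), a step within the ordinary scatter. On that basis compound 4 is expected to give a number close to that of compound 3, with a 1.6-fold higher number from compound 3 to compound 4 (0.20 log units; within the scatter) as the estimated step. For compound 4 the expected value in this assay is therefore 75000 nM, plausibly lying between 30000 nM and 180000 nM.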

Compound 4, half-maximal inhibitory concentration: 76600 nM
For compound 4 the middle estimate is 1.0-fold (0.01 log units) below the measured one; the range from low to high includes it.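

In this assay, putting bromo in place of methoxy on the carboxylic acid compounds gives a 1.6-fold higher number from compound 3 to compound 4 (0.21 log units; within the scatter), a step too small to separate from the ordinary spread of repeat measurements. Set beside the same swap on the ester compounds, which also carry a different amine side chain, the change reads alike in both settings: the same change on two cores in this assay, a 1.6-fold higher number (0.20 log units; within the scatter) from compound 1 to compound 2 and a 1.6-fold higher number (0.21 log units; within the scatter) from compound 3 to compound 4, 1.0-fold (0.01 log units) apart, within the scatter of two such steps So, in these two pairs, moving from 4-methoxyphenyl to 4-bromophenyl leaves no readable mark on either core, but this agreement is between two steps that are both within the scatter, and it does not show that the change has a real effect of a fixed size that carries over to other cores.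

The compounds shown leave open whether any other group at the same place on the phenyl ring, such as an amine, a nitrile or a hydroxyl, would move the number beyond the scatter on either core. They also leave open how much the carboxylic acid and the ester each contribute apart from the side chain, since those two features change together here, and whether a longer chain in place of the piperidine would matter.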